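The compounds below may be only part of what the source reports. "The series", "measured", "known", "first", "only" and "open" are said of these compounds alone.

Measured compounds in an assay on RKO cells for inhibition of ubiquitin carboxyl-terminal hydrolase 7 (Homo sapiens), read by a luciferase reporter, with a stated time of 18 h; a lower number here means that less compound is needed, a higher number that more compound is needed for the effect:

compound 1, `Cc1cc(Cl)cc(-c2ccnc3cc(CN4C(=O)CCC4=O)sc23)c1O[C@H]1C[C@H](N)C1`: 150 nM
compound 2, `Cc1cc(Cl)cc(-c2ccnc3cc(CN4C(=O)C5CC5C4=O)sc23)c1C[C@@H]1CNC[C@@H](C)O1`: 60 nM
compound 3, `Cc1cc(Cl)cc(-c2ccnc3cc(CN4C(=O)C5CC5C4=O)sc23)c1C[C@H]1OCCN[C@@H]1C`: 210 nM

Among these three, compound 1 stands second highest. Its nearest neighbour is compound 3, and the gap between them lies within the scatter of this assay, so the two cannot be ranked against each other. Compound 2 is the furthest from compound 1, and that gap lies beyond the scatter.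

Compound 4, `Cc1cc(Cl)cc(-c2ccnc3cc(CN4C(=O)CCC4=O)sc23)c1O[C@H]1CCCNC1`, is the compound not yet measured. It differs from compound 1 in one place: piperidin-3-yl in place of 3-aminocyclobutyl on an oxygen on an aromatic ring. Both the group that leaves and the group that enters carry one hydrogen-bond donor and one hydrogen-bond acceptor, and the point of attachment, the oxygen on the aromatic ring, is kept.

Within the data shown here, the only measured step, a 3.5-fold higher number from compound 2 to compound 3 (0.54 log units; beyond the scatter), concerns a different part of the structure and a different pair of compounds, so it does not bear on the change from compound 1 to compound 4. Among the measured compounds shown here, with no step that speaks to this exchange, the expectation for compound 4 rests on compound 1 alone, and the step is expected to be a 1.3-fold higher number from compound 1 to compound 4 (0.12 log units; within the scatter), that is, nothing beyond the scatter. Compound 4 is therefore estimated at 200 nM in this assay, within a range from 70 nM to 600 nM.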

Compound 4, half-maximal effective concentration: 180 nM
Estimate against measurement, compound 4: 1.1-fold (0.05 log units) above; low and high end bracket the measured number.
By their numbers in this assay, from the lowest: compound 2; then compounds 1, 4 and 3 (each within the scatter of the next).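

In this assay, putting piperidin-3-yl in place of 3-aminocyclobutyl on the oxygen on the aromatic ring gives a 1.2-fold higher number from compound 1 to compound 4 (0.08 log units; within the scatter), so the two groups cannot be ranked against each other. Among the earlier compounds only compound 1 carried a group on this oxygen, so they said nothing about exchanging it; this pair shows that a four-membered carbon ring with an amine on it and two defined stereocentres can be swapped for a six-membered ring with its nitrogen in the ring and one defined stereocentre, with no change beyond the scatter. Nothing measured here explains why these two groups read alike.

On these data alone, a single pair cannot show how much of the ring or its nitrogen this position needs, and what a cyclohexyl group, with carbon only in its ring, or a chain ending in a carboxylic acid would do on this oxygen stays open. Also open, as far as these compounds go, is whether piperidin-3-yl with the opposite arrangement at its stereocentre would give a similar number, or whether the arrangement at that centre matters.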